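From a fluoromethyl chain to an all-carbon chain

This account rests on a few compounds, and the source may have more. Where it says the series, first, only, none or still open, it means among the compounds named here.

Compound 1 `COC[C@H](C)[C@@H](C)C(c1ccc(O)c(OC)c1)c1ccc(O)c(OC)c1`: 77000 nM
Compound 2 `COc1cc(C(c2ccc(O)c(OC)c2)[C@@H](C)[C@H](C)CF)ccc1O`: 37000 nM

In a functional assay on HeLa cells (Homo sapiens) for cytotoxicity, read by WST assay, with a stated time of 48 h (a lower number here means a stronger inhibitor, a higher number a weaker inhibitor), compound 2 gives the lower of the two numbers, 37000 nM. Compound 3 `CC[C@H](C(C)C)C(c1ccc(O)c(OC)c1)c1ccc(O)c(OC)c1` brings 1-isopropylpropyl in place of 2-(fluoromethyl)-1-methylpropyl on a saturated chain carbon bound to two aromatic carbons. Among the compounds with values here, only one measured step bears on this, a 2.1-fold lower number from compound 1 to compound 2 (0.32 log units; beyond the scatter), and it is modest. It altered the same group, but offers only an indirect guide to this replacement. No clear shift is therefore expected. The estimated step is a 1.1-fold lower number from compound 2 to compound 3 (0.02 log units; within the scatter). Compound 3 is expected at 35000 nM, with an estimated range of 14000 nM to 85000 nM.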

Compound 3, half-maximal inhibitory concentration: 9700 nM
Compound 3: the middle estimate sits 3.6-fold (0.56 log units) above what was measured; the whole stated range lies above it.
By their numbers in this assay, from the lowest: compound 3; then compound 2; then compound 1.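

In this assay, 1-isopropylpropyl, a chain of carbon alone, gives the lowest number of the three on a saturated chain carbon bound to two aromatic carbons, with a 3.8-fold lower number from compound 2 to compound 3 (0.58 log units; beyond the scatter) and a 7.9-fold lower number from compound 1 to compound 3 (0.90 log units; beyond the scatter) as its two steps. Both steps lie beyond the scatter, so at this place neither 2-(fluoromethyl)-1-methylpropyl nor 2-(methoxymethyl)-1-methylpropyl matches the all-carbon chain. Nothing measured here accounts for this shift. Still open, as far as these compounds go, is whether an amine, a carboxylic acid or a longer chain at this place would lower the number further or raise it.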